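Cyclohexyl to Isopropyl on the Amide Carbonyl

The source may hold more compounds than are shown below. What is called first, only, known or untested is meant among the compounds shown, and "the series" means these compounds.

Compound 1 `COC(=O)/C=C/c1cccc(N(Cc2ccc(/C=C/c3cc(C(F)(F)F)cc(C(F)(F)F)c3)cc2)C(=O)C2CCCCC2)c1` and compound 2 `COC(=O)/C=C/c1cccc(N(Cc2ccc(/C=C/c3cc(C(F)(F)F)cc(C(F)(F)F)c3)cc2)C(=O)C(C)C)c1` share one core, while compound 3 `COC(=O)/C=C/c1cccc(N(Cc2ccc(-c3ccc(OC)cc3)cc2)C(=O)C2CCCCC2)c1` and compound 4 `COC(=O)/C=C/c1cccc(N(Cc2ccc(-c3ccc(OC)cc3)cc2)C(=O)C(C)C)c1` share another; the difference between the two cores is not broken down here. In an assay on isolated protein with Bile acid receptor (Homo sapiens) as the target (a lower number here means that less compound is needed, a higher number that more compound is needed for the effect), compound 1 gives 1470 nM and compound 2 gives 1950 nM. The change between them, (isopropyl in place of cyclohexyl on a carbonyl carbon), produced a 1.3-fold higher number from compound 1 to compound 2 (0.12 log units; within the scatter). In this assay compound 3 gives 89 nM, the lowest number of the three measured. Compound 4 carries the same change on the second core, (isopropyl in place of cyclohexyl on a carbonyl carbon), at the same place. Because the earlier step of a 1.3-fold higher number from compound 1 to compound 2 (0.12 log units; within the scatter) stayed within the scatter, a similarly small step is expected here, a 1.2-fold higher number from compound 3 to compound 4 (0.09 log units; within the scatter). In this assay compound 4 is therefore estimated at 110 nM, with a range from 55 nM to 230 nM.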

Compound 4, half-maximal effective concentration: 97 nM
Compound 4: middle estimate off by 1.1-fold (0.05 log units), on the high side; measured number inside the range.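

In this assay, isopropyl in place of cyclohexyl on the carbonyl carbon gave a 1.1-fold higher number from compound 3 to compound 4 (0.04 log units; within the scatter), so on the second core, as on the first, the change left the number within the scatter. The two steps agree: the same change on two cores in this assay, a 1.3-fold higher number (0.12 log units; within the scatter) from compound 1 to compound 2 and a 1.1-fold higher number (0.04 log units; within the scatter) from compound 3 to compound 4, 1.2-fold (0.09 log units) apart, within the scatter of two such steps. This shows that the change can be carried between these two cores without a step beyond the scatter, but it does not show that the same would hold on any other core in the series, and two pairs give no explanation for the result.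

The compounds shown leave open how a longer chain or an amine on the carbonyl carbon would compare with cyclohexyl and isopropyl. They also leave open how a carboxylic acid in place of the methyl ester would read in this assay.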